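Swapping the Aniline Substituent Once More

The source may report more compounds than this note shows. Statements on the series, on what has been measured and on what is new or still open speak of the compounds shown alone.

Measured so far:
Compound 1 `C=CC(=O)Nc1cccc(NC(=O)CSc2nc(Nc3ccccc3)c3ccccc3n2)c1`: 8120 nM
Compound 2 `C=CC(=O)Nc1cccc(NC(=O)CSc2nc(Nc3ccccc3Cl)c3ccccc3n2)c1`: 10000 nM
Compound 3 `C=CC(=O)Nc1cccc(NC(=O)CSc2nc(Nc3ccccc3C)c3ccccc3n2)c1`: 9920 nM

In a functional assay on NCI-H1975 cells (Homo sapiens) for inhibition, read by MTT assay, with a stated time of 72 h (on this read-out lower numbers stand for stronger inhibition and higher numbers for weaker inhibition), compound 3 gives 9920 nM, and its values and those of compound 1 and compound 2 lie within the scatter of one another. Compound 4 `C=CC(=O)Nc1cccc(NC(=O)CSc2nc(Nc3cccc(F)c3)c3ccccc3n2)c1` differs from compound 3 by 3-fluorophenyl in place of 2-methylphenyl on a nitrogen on an aromatic ring. The steps already seen on this same ring, a 1.2-fold higher number from compound 1 to compound 3 (0.09 log units; within the scatter), a 1.2-fold higher number from compound 1 to compound 2 (0.09 log units; within the scatter) and a 1.0-fold lower number from compound 2 to compound 3 (0.00 log units; within the scatter), all stayed within the scatter. The change to a 3-fluorophenyl group is therefore expected to give a 1.1-fold lower number from compound 3 to compound 4 (0.04 log units; within the scatter), with no shift beyond the scatter. Compound 4 is estimated at 9000 nM in this assay, within a range from 4000 nM to 20000 nM.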

Compound 4, half-maximal inhibitory concentration: 2030 nM
Compound 4: the middle estimate sits 4.4-fold (0.65 log units) above what was measured, and the stated range ends above it.
By their numbers in this assay, from the lowest: compound 4; then compounds 1, 3 and 2 (each within the scatter of the next).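

Among the compounds shown here, this position can move the number after all: fluoro on the ring gives a 4.0-fold lower number from compound 1 to compound 4 (0.60 log units; beyond the scatter), the first step here beyond the scatter. The 3-fluorophenyl group also stands apart from the two groups it replaces, with a 4.9-fold lower number from compound 3 to compound 4 (0.69 log units; beyond the scatter) and a 4.9-fold lower number from compound 2 to compound 4 (0.69 log units; beyond the scatter). Nothing measured here bears on why this happens.

Still open, as far as these compounds go, is whether the fluoro itself or its place on the ring carries this step. A 2-fluorophenyl, 3-chlorophenyl or 3-methylphenyl group would separate the two, and a ring bearing an amine or a carboxylic acid would test the position further.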